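The source may report more compounds than this note shows. Statements on the series, on what has been measured and on what is new or still open speak of the compounds shown alone.

In a functional assay on HL-60 cells (Homo sapiens) for cytotoxicity, read by ELISA, with a stated time of 2 days (on this read-out higher numbers stand for weaker inhibition and lower numbers for stronger inhibition), compound 1 (`Oc1ccccc1-c1cc(-c2ccccc2)cc(-c2ccccc2O)n1`) gives 22400 nM, compound 2 (`Oc1cccc(-c2cc(-c3ccccc3)cc(-c3cccs3)n2)c1`) gives 14100 nM and compound 3 (`Oc1cccc(-c2cc(-c3ccccc3)nc(-c3ccsc3)c2)c1`) gives 12000 nM. These numbers lie within the usual scatter of one another, so compound 3 stands level with the other two. Compound 4 (`Oc1cccc(-c2cc(-c3ccccc3)nc(-c3ccncc3)c2)c1`) has pyridin-4-yl in place of thiophen-3-yl on an aromatic carbon. No measured pair differs in just one place, so the effect of such a swap has not been shown directly. Even compound 1 at 22400 nM stays within the scatter of compound 3, so no step beyond the scatter is expected in this assay, in either direction. The estimated step is a 1.3-fold higher number from compound 3 to compound 4 (0.10 log units; within the scatter). For compound 4 the estimated value is 15000 nM, with an expected range from 6000 nM to 40000 nM.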

Compound 4, half-maximal inhibitory concentration: 12700 nM
The estimate for compound 4 lay 1.2-fold (0.07 log units) above the measured number, and the stated range covers the measured number.
By their numbers in this assay, from the lowest: compounds 3, 4, 2 and 1 (each within the scatter of the next).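

In this assay, within the data shown here, pyridin-4-yl in place of thiophen-3-yl gives a 1.1-fold higher number from compound 3 to compound 4 (0.02 log units; within the scatter), the first direct comparison here between compounds that differ in one place. At this aromatic carbon next to the ring nitrogen, a six-membered aromatic ring with nitrogen and a five-membered aromatic ring with sulfur therefore stand level. No measurement shown explains this result. As far as these compounds go, it remains open whether an amine, a carboxylic acid or a longer chain at this position would also stand level with these two rings.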